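The compounds below may be only part of what the source reports. "The series", "measured", "known", "first", "only" and "open" are said of these compounds alone.

Compound 1, `CCN(CC)S(=O)(=O)c1ccc(S(=O)(=O)N2CCC[C@@H](C(=O)N3CCN(c4nc(C(F)(F)F)no4)CC3)C2)cc1`, is a sulfonamide built on a shared core and tested in a functional assay on MIA PaCa-2 cells (Homo sapiens) for inhibition, read by MTT assay, with a stated time of 7 days (a higher number here means a weaker inhibitor, a lower number a stronger inhibitor), where compound 1 gives 600 nM. Among the two numbers on hand this is the lowest, and so the strongest inhibition recorded here. Compound 3, `CCOC(=O)[C@@H]1C[C@@H](O)CN(S(=O)(=O)c2ccc(S(=O)(=O)N(CC)CC)cc2)C1`, gives in this assay a value of 7900 nM, and its gap to compound 1 lies beyond the usual scatter of repeated measurements. Compound 2, `CCN1CC(NC(=O)[C@@H]2CCCN(S(=O)(=O)c3ccc(S(=O)(=O)N(CC)CC)cc3)C2)C1`, is reported only as the limit of > 30000 nM in this assay, at which 1 of the 3 values shown sits, so for compound 2 the figure > 30000 nM is a limit of the assay and not a number.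

Compound 4, `CCN(CC)S(=O)(=O)c1ccc(S(=O)(=O)N2CCC[C@@H](C(=O)N3CCN(c4nc(C(C)C)no4)CC3)C2)cc1`, differs from compound 1 at a single place: isopropyl in place of trifluoromethyl on an aromatic carbon. Within the data shown here, no two measured compounds differ in only one place, so no measured step of comparable kind is available to guide the expectation. The exchange swaps one small, uncharged group for another of similar size, neither carrying donors or acceptors. The step from compound 1 to compound 4 is therefore expected to be small, within the scatter or at most a slight move toward a weaker inhibitor. Compound 4 is expected to give about 1000 nM in this assay, between 300 nM and 4000 nM. This estimate is expected to mean a step of a 1.7-fold higher number from compound 1 to compound 4 (0.22 log units; within the scatter), within the usual scatter.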

Compound 4, half-maximal inhibitory concentration: 50 nM
Estimate against measurement, compound 4: 20-fold (1.30 log units) above; measured number below the stated range.
By their numbers in this assay, from the lowest: compound 4; then compound 1; then compound 3. At a limit, above all of these: compound 2.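

In this assay, putting isopropyl in place of trifluoromethyl on the aromatic carbon between two ring nitrogen atoms gives a 12-fold lower number from compound 1 to compound 4 (1.08 log units; beyond the scatter) and so counts as a large step, even though neither group carries a ring, a charge, or any hydrogen-bond donors or acceptors. The earlier compounds shown here offered no pair differing in one place, whereas this pair shows that the group at this position alone can move the number well beyond the scatter, and that the counts for the two groups do not foretell such a move. Nothing measured here bears on why the step is so large.

Only two groups are shown at this position, so it remains open whether methyl, a longer chain such as n-butyl, a cyclopropyl ring or an amine would give a number nearer to compound 4 or to compound 1. Going by these compounds, it also remains open whether the same exchange would give a step of this size on a core other than that of compound 1, since a single pair cannot establish a general rule.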